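The source may report more compounds than this note shows. Statements on the series, on what has been measured and on what is new or still open speak of the compounds shown alone.

Compounds measured in an ADME assay on HepG2 cells (Homo sapiens) for cytotoxicity; on this read-out higher numbers stand for an effect only at larger amounts of compound and lower numbers for an effect already at smaller amounts:
Compound 1 `Cc1ccc(S(=O)(=O)N[C@@H](CC(=O)NC(C)(C)C)C(=O)NCCNC(=O)c2cc(Cl)ccn2)cc1` gives > 11000 nM, which is a limit of the assay rather than a number.
Compound 2 `Cc1ccc(S(=O)(=O)N[C@@H](CC(=O)NC(C)(C)C)C(=O)NCCNC(=O)c2ccccc2Cl)cc1` gives > 11000 nM, again a limit of the assay.
Compound 3 `Cc1ccc(S(=O)(=O)N[C@@H](CC(=O)NC(C)(C)C)C(=O)NCCNC(=O)c2cccc(C#N)c2)cc1` gives > 11000 nM, once more a limit of the assay.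

All three measured compounds share one core and differ only in the aryl group on the carbonyl carbon. Every one of them sits at the same limit in this assay, as summarised by the limit of > 11000 nM in this assay, at which 3 of the 3 values shown sit. For the measured compounds named here, none of the measured steps can be read: the step that the two limits leave unreadable from compound 1 to compound 2, the step that the two limits leave unreadable from compound 1 to compound 3 and the step that the two limits leave unreadable from compound 2 to compound 3 each run between two limits and show neither size nor direction. Compound 3 therefore stands at the limit, indistinguishable from compounds 1 and 2 on the numbers at hand.

Compound 4 `C#Cc1cccc(C(=O)NCCNC(=O)[C@H](CC(=O)NC(C)(C)C)NS(=O)(=O)c2ccc(C)cc2)c1` is the next compound to be measured. It differs from compound 3 as follows: ethynyl in place of cyano on an aromatic carbon. The measured steps that change the aryl group on the carbonyl carbon all bear on it, but each is unreadable, so they give no basis for a step beyond the scatter in either direction. The estimated step from compound 3 is a number no higher from compound 3 to compound 4 (the limit leaves the size open). Compound 4 is accordingly expected to give about 11000 nM in this assay, within a range of 4000 nM to 30000 nM, most likely reported again as a limit.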

Compound 4, half-maximal effective concentration: > 11000 nM
Compound 4 was reported as a limit; the forecaster's own chance of this, stated with the estimate: 85%; the middle value sits exactly at the limit.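

In this assay compound 4 gives > 11000 nM as a limit of the assay and not a number. Its steps from compounds 1, 2 and 3 cannot be read, in size or in direction, as all four compounds stand at one limit: the limit of > 11000 nM in this assay, at which 4 of the 4 values shown sit. The compounds shown leave open how far apart they lie and whether any aryl group here gives a readable value.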